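Chloro to cyano on the benzyl ring: expected cytotoxicity

The source may report more compounds than this note shows. Statements on the series, on what has been measured and on what is new or still open speak of the compounds shown alone.

Measured so far:
compound 1, `O=[N+]([O-])c1cn2c(n1)OC[C@@H](OCc1ccc(-c3ccc(OC(F)(F)F)cc3)cc1Cl)C2`: > 128000 nM
compound 2, `O=[N+]([O-])c1cn2c(n1)OC[C@@H](OCc1c(Cl)cc(-c3ccc(OC(F)(F)F)cc3)cc1Cl)C2`: > 128000 nM

In an ADME assay on Vero cells (Chlorocebus sabaeus) for cytotoxicity, with a stated time of 72 h (on this read-out higher numbers stand for weaker inhibition and lower numbers for stronger inhibition), compound 1 gives > 128000 nM, which is a limit of the assay and not a number. Compound 2 likewise gives only a limit, > 128000 nM. For the measured compounds named here, the step that the two limits leave unreadable from compound 1 to compound 2 is therefore unreadable, the only evidence being (the limit of > 128000 nM in this assay, at which 2 of the 2 values shown sit). Compound 3 `N#Cc1cc(-c2ccc(OC(F)(F)F)cc2)ccc1CO[C@@H]1COc2nc([N+](=O)[O-])cn2C1` differs from compound 1 by cyano in place of chloro on an aromatic carbon. Going by the values given here, no measured step gives a readable size, so for compound 3 the estimate is 150000 nM, with a range from 50000 nM to 500000 nM, an expected step that the limit leaves unreadable from compound 1 to compound 3 not beyond the scatter, most likely again reported as a limit.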

Compound 3, half-maximal inhibitory concentration: > 128000 nM
Compound 3 ended at the assay's limit (the forecaster's own chance of this, stated with the estimate: 85%); the middle value does not contradict the limit.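

The step from compound 1 to compound 3 cannot be read, since both results in this assay are limits and not numbers: the limit of > 128000 nM in this assay, at which 3 of the 3 values shown sit.

The compounds shown leave open whether compound 1, compound 2 and compound 3 truly differ in cytotoxicity, and at what concentration any of them would inhibit these cells.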